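Para substituent series on the styryl-piperidine core

This account rests on a few compounds, and the source may have more. Where it says the series, first, only, none or still open, it means among the compounds named here.

Compound 1 `CC(=O)c1ccc(/C=C/[C@@H]2CCCCN2)cc1` and compound 2 `Cc1ccc(/C=C/[C@@H]2CCCCN2)cc1` differ only at the substituent on the aromatic ring. In a functional assay on OVCAR-3 cells (Homo sapiens) for inhibition, read by MTT assay, with a stated time of 24 h (on this read-out higher numbers stand for weaker inhibition and lower numbers for stronger inhibition), compound 1 gives 2.18 ug/mL, while compound 2 gives 8.48 ug/mL; the step of a 3.9-fold higher number from compound 1 to compound 2 (0.59 log units; beyond the scatter) is the only measured one in the set, and compound 2 therefore holds the higher of the two numbers. Compound 3 `COc1ccc(/C=C/[C@@H]2CCCCN2)cc1` carries the next change, (methoxy in place of methyl on an aromatic carbon). Among the measured compounds shown here, no measured step in this assay concerns a methoxy group; the acetyl-to-methyl step from compound 1 to compound 2 touches the same position but not the same groups, so it bears only loosely. With so little to go on, the number for compound 3 is expected to sit close to that of compound 2, the step of a 1.3-fold lower number from compound 2 to compound 3 (0.12 log units; within the scatter) being small and within the scatter. The estimate for compound 3 is 6.5 ug/mL, with a range from 2.5 ug/mL to 16 ug/mL.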

Compound 3, half-maximal inhibitory concentration: 3.31 ug/mL
The estimate for compound 3 lay 2.0-fold (0.29 log units) above the measured number; the range from low to high includes it.
By their numbers in this assay, from the lowest: compounds 1 and 3 (each within the scatter of the next); then compound 2.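

In this assay, methoxy in place of methyl gives a 2.6-fold lower number from compound 2 to compound 3 (0.41 log units; beyond the scatter), a step beyond the scatter, which leaves compound 2 as the weakest of the three compounds. Methoxy in place of acetyl gives a 1.5-fold higher number from compound 1 to compound 3 (0.18 log units; within the scatter), a step within the scatter, so this read-out does not separate these two groups at this position, while both stand apart from methyl. No measurement on hand accounts for either step.

Compound 1 and compound 3 both carry an oxygen in the group at this position and compound 2 does not, but three compounds cannot show whether that oxygen is what matters. As far as these compounds go, a hydroxyl, an amine or a carboxylic acid at this position, or a longer chain in place of methoxy, remains open.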